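Dropping the amino acid arm from a quinone core

A few compounds are considered here, and "the series" means these few. Any claim that something is new, unique, unknown or untested is made for them only; others in the source may bear on it.

Measured so far:
Compound 1, `CSCC[C@H](NC1=CC(=O)C=C(C(C)(C)C)C1=O)C(=O)O`, gives 34800 nM in a functional assay on Fem-X cells (Homo sapiens) for cytotoxicity, read by MTT assay, with a stated time of 72 h; on this read-out higher numbers stand for weaker inhibition and lower numbers for stronger inhibition.
Compound 2, `CC1=CCC[C@H]2[C@](C)(CC3=CC(=O)C=C(NCC(=O)O)C3=O)[C@@H](C)CC[C@]12C`, gives 17800 nM in this assay.
Compound 3, `CC(C)C[C@H](NC1=CC(=O)C=C(C(C)(C)C)C1=O)C(=O)O`, gives 39400 nM in this assay.

Compound 2 has the lowest number of the three, though its gap to compound 1 is within the scatter and only its gap to compound 3 is beyond it. Compound 4, `CC1=CCC[C@H]2[C@](C)(CC3=CC(=O)C=CC3=O)[C@@H](C)CC[C@]12C`, differs from compound 2 in one place: hydrogen in place of (carboxymethyl)amino on a double-bonded ring carbon. Going by the values given here, the only step measured so far, a 1.1-fold higher number from compound 1 to compound 3 (0.05 log units; within the scatter), concerns a different change on a different core, so nothing measured bears directly on this one. The expected step of a 1.5-fold lower number from compound 2 to compound 4 (0.17 log units; within the scatter) is therefore uncertain and taken as small. Compound 4 is estimated at 12000 nM, with a range from 2500 nM to 60000 nM.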

Compound 4, half-maximal inhibitory concentration: 40300 nM
For compound 4 the middle estimate is 3.4-fold (0.53 log units) below the measured one; the range from low to high includes it.
By their numbers in this assay, from the lowest: compounds 2, 1, 3 and 4 (each within the scatter of the next, the first and the last beyond it).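

Replacing the (carboxymethyl)amino group with hydrogen gives a 2.3-fold higher number from compound 2 to compound 4 (0.35 log units; beyond the scatter) in this assay, so on this core the group on the double-bonded ring carbon goes with the stronger inhibition of the pair. The step is modest, but unlike the earlier side-chain change on the other core, it lies beyond the scatter. Nothing available explains this difference.

The compounds shown do not separate the part played by the nitrogen from that of the acid. As far as these compounds go, an amine alone on this carbon, or a longer chain ending in a carboxylic acid, remains open.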